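Notes on compound 4: methyl groups on the benzyl ring

This account rests on a few compounds, and the source may have more. Where it says the series, first, only, none or still open, it means among the compounds named here.

Measured so far:
- compound 1 `N#Cc1ccc(OCc2ccsc2)cc1OC(C(=O)O)c1ccccc1C(F)(F)F` — in an assay on A10 cells for antagonist activity at Endothelin-1 receptor (Rattus norvegicus) (on this read-out lower numbers stand for stronger inhibition and higher numbers for weaker inhibition), compound 1 gives 53 nM
- compound 2 `N#Cc1ccc(OCc2ccsc2)cc1OC(C(=O)O)c1ccco1` — in this assay compound 2 gives 2400 nM
- compound 3 `Cc1ccccc1C(Oc1cc(OCc2ccccc2)ccc1C#N)C(=O)O` — in this assay compound 3 gives 49 nM

Compound 3 sits at the low end of the numbers shown, alongside compound 1 within the scatter, and far below compound 2. Within the data shown here, the single step between neighbours, a 45-fold higher number from compound 1 to compound 2 (1.66 log units; beyond the scatter), concerns the group on the carbon bound to the carbonyl and the aryl oxygen, not the benzyloxy side. Compound 4 `Cc1ccccc1C(Oc1cc(OCc2c(C)cccc2C)ccc1C#N)C(=O)O` differs from compound 3 by 2,6-dimethylphenyl in place of phenyl on a saturated chain carbon bound to an oxygen on an aromatic ring. Among the measured compounds shown here, no measured step touches this position, so nothing supports a direction; the expected step is small, within the scatter: a 1.0-fold higher number from compound 3 to compound 4 (0.01 log units; within the scatter) is anticipated. Compound 4 is therefore estimated at 50 nM in this assay, with a range of 18 nM to 140 nM.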

Compound 4, half-maximal inhibitory concentration: 857 nM
The estimate for compound 4 lay 17-fold (1.23 log units) below the measured number; the whole stated range lies below it.
By their numbers in this assay, from the lowest: compounds 3 and 1 (each within the scatter of the next); then compound 4; then compound 2.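

In this assay the benzyloxy side proves responsive: 2,6-dimethylphenyl in place of phenyl gives a 17-fold higher number from compound 3 to compound 4 (1.24 log units; beyond the scatter), whereas the earlier step spoke only to the group on the carbon bound to the carbonyl. The change adds two carbons as methyl groups, with no hydrogen-bond donors or acceptors and no net charge. No available data bear on the reason for this step.

Going by these compounds, whether a single methyl group on this ring would give a step of similar size remains open. On these data alone, how a chlorine or a methoxy group on the same ring would read is also open.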